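Methyl on an aromatic nitrogen: compound 2 to compound 3

This account rests on a few compounds, and the source may have more. Where it says the series, first, only, none or still open, it means among the compounds named here.

Measured so far:
compound 1, `COc1c(C)ccc2c1CCC2c1ncc[nH]1`: > 10000 nM
compound 2, `c1cc(-c2ccn[nH]2)c2c(c1)C(c1ncc[nH]1)CC2`: 600 nM

Going by the values given here, in a functional assay on CHO cells for agonist activity at Alpha-1B adrenergic receptor (Homo sapiens), read by FLIPR and calcium flux (on this read-out lower numbers stand for an effect already at smaller amounts and higher numbers for an effect only at larger amounts of compound), compound 2 gives the only plain number. For compound 1 the reported value is a limit of the assay (the limit of > 10000 nM in this assay, at which 1 of the 2 values shown sits). Compound 3, `Cn1nccc1-c1cccc2c1CCC2c1ncc[nH]1`, is not yet measured. It differs from compound 2 by methyl in place of hydrogen on an aromatic nitrogen. Among the compounds with values here, no measured pair shows a step of this kind, so its size is open; a modest loss, or nothing beyond the scatter, is expected. For compound 3 the estimated value in this assay is 1000 nM, between 300 nM and 4000 nM. The expected step from compound 2 to compound 3 is a 1.7-fold higher number from compound 2 to compound 3 (0.22 log units; within the scatter).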

Compound 3, half-maximal effective concentration: > 10000 nM
Compound 3: no number, only a limit (the forecaster's own chance of this, stated with the estimate: 15%); at least 10-fold (1.00 log units) between middle value and limit.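

In this assay, going by these compounds alone, this is the first pair differing in one place, and it shows that the position is sensitive to this change: methyl in place of hydrogen on an aromatic nitrogen gives an at least 16-fold higher number from compound 2 to compound 3 (1.22 log units; beyond the scatter). Compound 3 stands at > 10000 nM, a limit of the assay and not a number, so the step has a lower bound only: the limit of > 10000 nM in this assay, at which 2 of the 3 values shown sit.

On this nitrogen, only hydrogen and methyl are shown. Going by these compounds, whether ethyl or a longer chain would match methyl stays open.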